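The compounds below may be only part of what the source reports. "The series", "measured", "known", "first", "only" and "open" are said of these compounds alone.

Of the compounds shown here, two of the shared core carry a measured number so far. Compound 1 `Cc1cccc(C)c1C(=O)Nc1nnc(-c2ccc(Cl)cc2)s1` in a functional assay on the whole organism (integument) for inhibition, with Chilo suppressalis as the target, read by scintillation counting, with a stated time of 72 h (a lower number here means a stronger inhibitor, a higher number a weaker inhibitor), gives 69.2 nM. Compound 2 `COc1cccc(OC)c1C(=O)Nc1nnc(-c2ccc(Cl)cc2)s1` in this assay gives 58.9 nM. Compound 1 holds the highest of the two numbers, with compound 2 its nearest neighbour, and the two values lie within the scatter of each other, so no order between them is read from this pair. Within the data shown here, no step between measured compounds that differ in one place is at hand.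

Compound 3 `Cc1ccccc1C(=O)Nc1nnc(-c2ccc(Cl)cc2)s1` is not yet measured in this assay. Against compound 1 the change is hydrogen in place of methyl on an aromatic carbon: a methyl leaves and a hydrogen enters on an aromatic carbon of a six-membered aromatic ring of carbon only, ortho to a large group and meta to a methyl group. Among the measured compounds shown here, no measured pair shows such a change, so the size of the step is open; compound 3 keeps the remaining methyl only. A modest rise in the number, beyond the scatter but not large, is expected, and the expected step is a 1.6-fold higher number from compound 1 to compound 3 (0.20 log units; within the scatter). For compound 3 in this assay the estimate is 110 nM, within 40 nM to 300 nM.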

Compound 3, half-maximal inhibitory concentration: 158 nM
Compound 3: the middle estimate sits 1.4-fold (0.16 log units) below what was measured; the range from low to high includes it.
By their numbers in this assay, from the lowest: compounds 2 and 1 (each within the scatter of the next); then compound 3.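

In this assay, among these compounds, this is the first step that can be read at one place: hydrogen in place of methyl on an aromatic carbon, ortho to a large group and meta to a methyl group, gives a 2.3-fold higher number from compound 1 to compound 3 (0.36 log units; beyond the scatter) on the shared core. The position is therefore not indifferent to this change, although the step is modest, and compound 3 with its one remaining methyl still gives 158 nM in the same assay. No measurement at hand bears on why the loss of this methyl raises the number, so the step stands as an observation only.

Going by these compounds, whether the rise is tied to the methyl itself stays open, since a single step cannot separate it from what an ethyl group, a chlorine atom or a methoxy group would do at this place. Also open, on these data alone, are the same exchange on compound 2 and the effect of hydrogen in place of the remaining methyl of compound 3, so neither the size of the step elsewhere on this ring nor its additivity can be judged yet.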